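Working notes: from compound 2 to compound 3

The source may report more compounds than this note shows. Statements on the series, on what has been measured and on what is new or still open speak of the compounds shown alone.

- compound 1 `CCn1c(C(=O)NCCC(=O)OC)ccc1C(CC)(CC)c1ccc(C#CC(O)(CC)CC)c(C)c1`: > 50000 nM (a limit)
- compound 2 `CCCCC(=O)c1ccc(C(CC)(CC)c2ccc(C#CC(O)(CC)CC)c(C)c2)n1CC`: > 50000 nM (a limit)

All values come from a functional assay on MCF7 cells (Homo sapiens) for antiproliferative activity, read by MTT assay, with a stated time of 72 h; on this read-out higher numbers stand for weaker inhibition and lower numbers for stronger inhibition. In this assay compound 2 gives > 50000 nM, which is a limit and not a number. Its position is shared with compound 1: the limit of > 50000 nM in this assay, at which 2 of the 2 values shown sit. Compound 3 `CCn1c(C(=O)NCC(=O)O)ccc1C(CC)(CC)c1ccc(C#CC(O)(CC)CC)c(C)c1` has (carboxymethyl)amino in place of butyl on a carbonyl carbon. Among the compounds with values here, the only measured step, a step that the two limits leave unreadable from compound 1 to compound 2, offers no size to carry over. Compound 1, also with an amino group on a carbonyl carbon, stands at the limit > 50000 nM. No readable gain is therefore expected, and the estimated step of a number no higher from compound 2 to compound 3 (the limit leaves the size open) is likely to stay within the scatter or be reported only as a limit. For compound 3 the expected value is 50000 nM, with an estimated range of 20000 nM to 100000 nM.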

Compound 3, half-maximal inhibitory concentration: 5140 nM
Compound 3: the middle estimate sits 9.7-fold (0.99 log units) above what was measured, outside the stated range (below it).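

In this assay the group on the carbonyl carbon now gives a readable result: (carboxymethyl)amino in place of butyl gives an at least 9.7-fold lower number from compound 2 to compound 3 (0.98 log units; beyond the scatter). An amino group there is not enough by itself: carboxy in place of (methoxycarbonyl)methyl on the saturated chain carbon gives an at least 9.7-fold lower number from compound 1 to compound 3 (0.98 log units; beyond the scatter). Only compound 3 stands clear of the limit: the limit of > 50000 nM in this assay, at which 2 of the 3 values shown sit.

Going by these compounds, the step between the two limit compounds cannot be read, and the full size of both new steps stays open. Also open, on these data alone, is whether a longer chain ending in a carboxylic acid, or an amine in place of the carboxy, would hold this gain.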